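Cytotoxicity of a dimethylthiazolyl analogue: an expectation

A few compounds are considered here, and "the series" means these few. Any claim that something is new, unique, unknown or untested is made for them only; others in the source may bear on it.

Compound 1 `CCOC(=O)c1c(-c2cccc(OC)c2)[nH]c2cc(OC)ccc2c1=O`: in an ADME assay on BJ cells (Homo sapiens) for cytotoxicity, read by luminescence, with a stated time of 72 h (on this read-out higher numbers stand for an effect only at larger amounts of compound and lower numbers for an effect already at smaller amounts), compound 1 gives > 21500 nM, which is a limit of the assay.
Compound 2 `CCOC(=O)c1c(-c2cccc(OC)c2)[nH]c2cc(OC)c(F)cc2c1=O`: in this assay compound 2 gives > 21500 nM, again a limit of the assay.

Compound 2 therefore stands at the limit, with no number of its own; both values shown sit at the limit of > 21500 nM in this assay, at which 2 of the 2 values shown sit. Among the measured compounds shown here, the single measured step, a step that the two limits leave unreadable from compound 1 to compound 2, cannot be read in size or direction for that reason.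

Compound 3 `CCOC(=O)c1c(-c2cccc(-c3nc(C)c(C)s3)c2)[nH]c2cc(OC)c(F)cc2c1=O` differs from compound 2 by 4,5-dimethyl-1,3-thiazol-2-yl in place of methoxy on an aromatic carbon. For the measured compounds named here, no measured step touches this change, and the only step there is, between two limits, gives no size to lean on. The expectation for compound 3 is therefore built on the limit alone: compound 3 is estimated at 30000 nM, within 8000 nM to 100000 nM, most likely reported as a limit again. The expected step that the limit leaves unreadable from compound 2 to compound 3 is thus estimated to stay within the usual scatter.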

Compound 3, half-maximal effective concentration: > 21500 nM
Compound 3 gave a limit, no number (the forecaster's own chance of this, stated with the estimate: 65%); the middle value does not contradict the limit.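

Among the compounds shown here, compound 2 and compound 3 both give a limit of the assay rather than a number, so no step between them can be read: the limit of > 21500 nM in this assay, at which 3 of the 3 values shown sit. The compounds shown leave open at what concentration compound 1, compound 2 or compound 3 would show an effect in this assay, and whether either change alters it.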